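Quinazoline thioacetamide series: dichlorophenyl replacement for trimethoxyphenyl

This account rests on a few compounds, and the source may have more. Where it says the series, first, only, none or still open, it means among the compounds named here.

Measured so far:
Compound 1 `C=CC(=O)Nc1cccc(NC(=O)CSc2nc(Nc3ccccc3F)c3ccccc3n2)c1` in a functional assay on MGC-803 cells (Homo sapiens) for inhibition, read by MTT assay, with a stated time of 72 h (on this read-out higher numbers stand for weaker inhibition and lower numbers for stronger inhibition), gives 26100 nM.
Compound 2 `C=CC(=O)Nc1cccc(NC(=O)CSc2nc(Nc3cccc(C)c3)c3ccccc3n2)c1` in this assay gives 20900 nM.
Compound 3 `C=CC(=O)Nc1cccc(NC(=O)CSc2nc(Nc3cc(OC)c(OC)c(OC)c3)c3ccccc3n2)c1` in this assay gives only a limit, > 50000 nM.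

Compound 3 thus stands at the weak end of the set, with no number of its own, only (the limit of > 50000 nM in this assay, at which 1 of the 3 values shown sits). The step of a 1.2-fold lower number from compound 1 to compound 2 (0.10 log units; within the scatter) stays within the scatter, whereas an at least 1.9-fold higher number from compound 1 to compound 3 (0.28 log units; that floor lies within the scatter) and an at least 2.3-fold higher number from compound 2 to compound 3 (0.37 log units; beyond the scatter) both run toward weaker inhibition. Compound 4 `C=CC(=O)Nc1cccc(NC(=O)CSc2nc(Nc3ccc(Cl)c(Cl)c3)c3ccccc3n2)c1` carries 3,4-dichlorophenyl in place of 3,4,5-trimethoxyphenyl on a nitrogen on an aromatic ring. The two steps leading into compound 3 are the ones that bear on this change; read in reverse, they suggest a return toward the values of compound 1 and compound 2. The expected step is an at least 2.0-fold lower number from compound 3 to compound 4 (0.30 log units; that floor lies within the scatter). Compound 4 is therefore estimated at 25000 nM in this assay, with a range from 10000 nM to 60000 nM.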

Compound 4, half-maximal inhibitory concentration: > 50000 nM
Compound 4 gave a limit, no number (the forecaster's own chance of this, stated with the estimate: 20%); at least 2.0-fold (0.30 log units) between middle value and limit.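

In this assay compound 4 gives only a limit, as compound 3 does, and the step between them cannot be read: the limit of > 50000 nM in this assay, at which 2 of the 4 values shown sit.

At this nitrogen, the 3,4-dichlorophenyl group shows an at least 2.3-fold higher number from compound 2 to compound 4 (0.37 log units; beyond the scatter) and an at least 1.9-fold higher number from compound 1 to compound 4 (0.28 log units; that floor lies within the scatter). The weak end of the set is therefore not confined to 3,4,5-trimethoxyphenyl; among these four compounds, only the two singly substituted phenyl groups give numbers.

As far as these compounds go, how far compound 3 and compound 4 lie past the limit remains open. So does whether a phenyl carrying one chlorine, or a dimethylamino group, at this place would return a number.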